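Compound 1 to compound 4: ethyl out, 4-methylphenyl in

The source may hold more compounds than are shown below. What is called first, only, known or untested is meant among the compounds shown, and "the series" means these compounds.

Compound 1 `CCn1ccnc1-c1cc(OC)c(OC)c(OC)c1`: > 100000 nM
Compound 2 `COc1cc(-c2nccn2S(=O)(=O)c2ccc(C)cc2)cc(OC)c1OC`: > 100000 nM
Compound 3 `COc1cc(-c2nccn2-c2ccc3cc[nH]c3c2)cc(OC)c1OC`: 1700 nM

In a functional assay on MDA-MB-468 cells (Homo sapiens) for antiproliferative activity, read by MTT assay, with a stated time of 72 h (on this read-out lower numbers stand for stronger inhibition and higher numbers for weaker inhibition), compound 1 gives > 100000 nM, a limit and not a number. Compound 2 gives > 100000 nM, also a limit. Compound 1 therefore stands at the limit of > 100000 nM in this assay, at which 2 of the 3 values shown sit. Compound 3 alone gives a number, 1700 nM.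

Compound 4 `COc1cc(-c2nccn2-c2ccc(C)cc2)cc(OC)c1OC` carries 4-methylphenyl in place of ethyl on an aromatic nitrogen. For the measured compounds named here, no measured step isolates this change. The reading from compound 3 at 1700 nM suggests that a number within the range of this assay is possible. Compound 2, however, stays at its limit. The expected step is an at least 12-fold lower number from compound 1 to compound 4 (1.09 log units; beyond the scatter), toward stronger inhibition and beyond the scatter. For compound 4 the estimate is 8000 nM, with an expected range from 1000 nM to 60000 nM.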

Compound 4, half-maximal inhibitory concentration: 400 nM
Estimate against measurement, compound 4: 20-fold (1.30 log units) above; measured number below the stated range.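

In this assay, 4-methylphenyl in place of ethyl on an aromatic nitrogen gives an at least 250-fold lower number from compound 1 to compound 4 (2.39 log units; beyond the scatter). This single change at this position is enough to move the series from a limit to a measured number. The size of the step is only a bound because compound 1 sits at a limit, not a number: the limit of > 100000 nM in this assay, at which 2 of the 4 values shown sit.

As far as these compounds go, whether the methyl adds anything beyond the phenyl ring remains open. So does how plain phenyl, benzyl or 4-aminophenyl on the same nitrogen would read in this assay.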